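Thiophen-2-yl in place of hydrogen on a ring carbon

The compounds below may be only part of what the source reports. "The series", "measured", "known", "first", "only" and "open" are said of these compounds alone.

Compound 1 `C=CC(=O)N1C(=O)CC(c2ccc(OC)cc2)Sc2ccccc21` gives 32900 nM
Compound 2 `C=CC(=O)N1C(=O)CC(c2ccc(Cl)cc2)Sc2ccccc21` gives 22600 nM
Compound 3 `C=CC(=O)N1C(=O)CCSc2ccccc21` gives 22400 nM

All three were tested in a functional assay on NB-4 cells (Homo sapiens) for cytotoxicity, read by CCK-8 assay, with a stated time of 24 h (a lower number here means a stronger inhibitor, a higher number a weaker inhibitor), and compound 3 stands within the scatter of both other compounds. Compound 4 `C=CC(=O)N1C(=O)CC(c2cccs2)Sc2ccccc21` has thiophen-2-yl in place of hydrogen on a saturated ring carbon of the core of compound 3 : thiophen-2-yl in place of hydrogen on a saturated ring carbon. Within the data shown here, no compound with thiophen-2-yl has been measured yet, so the nearest evidence comes from two steps that exchange an aromatic group on a saturated ring carbon for hydrogen. These are a 1.5-fold lower number from compound 1 to compound 3 (0.17 log units; within the scatter) and a 1.0-fold lower number from compound 2 to compound 3 (0.00 log units; within the scatter). The exchange of substituents on the aromatic ring, a 1.5-fold lower number from compound 1 to compound 2 (0.16 log units; within the scatter), also stays small. None of these steps leaves the scatter, so no step beyond the scatter is expected in this assay, in either direction. The expected step is a 1.1-fold higher number from compound 3 to compound 4 (0.05 log units; within the scatter). For compound 4 the estimated value is 25000 nM, with an expected range of 13000 nM to 45000 nM.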

Compound 4, half-maximal inhibitory concentration: 765000 nM
Compound 4: the middle estimate sits 31-fold (1.49 log units) below what was measured, and the stated range ends below it.
By their numbers in this assay, from the lowest: compounds 3, 2 and 1 (each within the scatter of the next); then compound 4.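

Among these compounds, at this saturated ring carbon next to the ring sulfur, the earlier compounds suggested tolerance, since 4-methoxyphenyl and 4-chlorophenyl both stayed within the scatter of hydrogen, but in this assay thiophen-2-yl gives a 34-fold higher number from compound 3 to compound 4 (1.53 log units; beyond the scatter). Exchanging one aromatic group for another at this carbon is therefore not neutral either, as shown by a 34-fold higher number from compound 2 to compound 4 (1.53 log units; beyond the scatter) and by a 23-fold higher number from compound 1 to compound 4 (1.37 log units; beyond the scatter), so having an aromatic ring at this position does not by itself set the outcome across these compounds. Nothing available explains why this one group stands so far from the others.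

From the compounds shown here alone, whether thiophen-3-yl, furan-2-yl or an unsubstituted phenyl at this carbon would behave like thiophen-2-yl or like the two substituted phenyl groups remains open. Also open, going by these compounds, is whether the large step would persist if a propanoyl group replaced the vinylcarbonyl group.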